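The compounds below may be only part of what the source reports. "The series", "measured", "known", "first", "only" and "open" are said of these compounds alone.

Compound 1 `CCOC(=O)c1cc(-c2cc(OC)c(OC)c(OC)c2)c(-c2ccc(OC)cc2)s1` gives in a functional assay on KB cells (Homo sapiens) for antiproliferative activity, read by MTT assay, with a stated time of 72 h (on this read-out higher numbers stand for weaker inhibition and lower numbers for stronger inhibition), a value of 13200 nM. Compound 2 `CCOC(=O)c1cc(-c2cc(OC)c(OC)c(OC)c2)c(-c2ccc(OC)c([N+](=O)[O-])c2)s1` differs from compound 1 by nitro in place of hydrogen on an aromatic carbon and in this assay compound 2 gives 15800 nM; the step of a 1.2-fold higher number from compound 1 to compound 2 (0.08 log units; within the scatter) is within the scatter. Compound 3 `COc1ccc(-c2ccsc2-c2cc(OC)c(OC)c(OC)c2)cc1` rests on another core; how the core of compound 3 differs from that of compound 1 is not broken down here. In this assay compound 3 gives 7400 nM, which sits within the scatter of compound 1 and beyond it only against compound 2.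

Compound 4 `COc1ccc(-c2ccsc2-c2cc(OC)c(OC)c(OC)c2)cc1[N+](=O)[O-]` has not been measured. Within the data shown here, it differs from compound 3 by nitro in place of hydrogen on an aromatic carbon, the same change as the one between compound 1 and compound 2, made at a place whose description matches word for word. Among the measured compounds shown here, the one measured instance of this change was a 1.2-fold higher number from compound 1 to compound 2 (0.08 log units; within the scatter), so a step of similar size is expected here. The step is estimated as a 1.1-fold higher number from compound 3 to compound 4 (0.06 log units; within the scatter). Compound 4 is therefore expected to give about 8500 nM in this assay, with a likely range from 4200 nM to 17000 nM.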

Compound 4, half-maximal inhibitory concentration: 21000 nM
Beside the measured number, compound 4's estimate is 2.5-fold (0.39 log units) below it; measured number above the stated range.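

In this assay, nitro in place of hydrogen on an aromatic carbon gives a 2.8-fold higher number from compound 3 to compound 4 (0.45 log units; beyond the scatter), whereas on the core of compound 1 the same change gave a 1.2-fold higher number from compound 1 to compound 2 (0.08 log units; within the scatter). Only the newer step lies beyond the scatter, yet the gap between the two steps does not, so the pair gives no firm sign that the core alters the effect of this change: the same change on two cores in this assay, a 1.2-fold higher number (0.08 log units; within the scatter) from compound 1 to compound 2 and a 2.8-fold higher number (0.45 log units; beyond the scatter) from compound 3 to compound 4, 2.4-fold (0.37 log units) apart, within the scatter of two such steps. Two instances neither establish that the change carries reliably from one core to the other nor show that it fails to carry, and they give no explanation for the larger step.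

The compounds shown leave open how an amine or a carboxylic acid in place of the nitro, ortho to a methoxy group, would behave on either core. They also leave open whether a third core carrying the same nitro change would give a step closer to the smaller or to the larger one.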